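The compounds below may be only part of what the source reports. "The series", "measured", "known", "first", "only" and "open" are said of these compounds alone.

In an ADME assay on HUVEC cells (Homo sapiens) for antiproliferative activity, with a stated time of 72 h (on this read-out higher numbers stand for weaker inhibition of growth and lower numbers for stronger inhibition of growth), compound 1 `COC(=O)[C@@H]1OC2(CCN(c3nc(=O)c4cc(C(F)(F)F)cc([N+](=O)[O-])c4s3)CC2)O[C@H]1c1ccccc1` gives > 50000 nM as its entry, which is a limit of the assay and not a number. Going by the values given here, compound 2 `COC(=O)C1CN(c2nc(=O)c3cc(C(F)(F)F)cc([N+](=O)[O-])c3s2)CCC12OC[C@H](C)O2` gives 16000 nM as the only true number so far, so it stands alone on the scale. Compound 3 `C[C@H]1COC2(CCN(c3nc(=O)c4cc(C(F)(F)F)cc([N+](=O)[O-])c4s3)CC2)O1` keeps the shared core but carries hydrogen in place of methoxycarbonyl on a saturated ring carbon, a change counted as hydrogen in place of methoxycarbonyl on a saturated ring carbon in full. Among the compounds with values here, no measured pair differing in one place is available, so the effect of this swap has not been seen. Resting on compound 2 at 16000 nM alone, no shift beyond the usual scatter is expected in this assay in either direction. The estimated change is a 1.1-fold lower number from compound 2 to compound 3 (0.06 log units; within the scatter) and remains uncertain. Compound 3 is expected at 14000 nM with an estimated range from 5000 nM to 50000 nM as the likely span.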

Compound 3, concentration for 50% growth inhibition: 8000 nM
Compound 3: middle estimate off by 1.8-fold (0.24 log units), on the high side; the measured number falls inside the stated range.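

Hydrogen in place of methoxycarbonyl on this saturated ring carbon, two ring bonds from the ring nitrogen, gives the first step that can be read in this assay: a 2.0-fold lower number from compound 2 to compound 3 (0.30 log units; within the scatter). This one pair shows that taking methoxycarbonyl off this position does not shift the number beyond the usual scatter, so the group is not required for the weak growth inhibition that compound 2 and compound 3 show here. Compound 1 gives only a limit of the assay and not a number, and no step to it can be read: the limit of > 50000 nM in this assay, at which 1 of the 3 values shown sits.

On these data alone, what a carboxylic acid, an amine or a longer chain on this same ring carbon would do remains open. A single pair also leaves open whether the same swap would give a similar step on any other core.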